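The compounds below may be only part of what the source reports. "The series", "measured", "known", "first", "only" and "open" are said of these compounds alone.

Compound 1 `C=CC1=C(C(=O)NCCC)C(c2ccc(F)cc2)OC1` — in a functional assay on QGY7701 cells (Homo sapiens) for cytotoxicity, read by MTT assay, with a stated time of 24 h (on this read-out lower numbers stand for stronger inhibition and higher numbers for weaker inhibition), compound 1 gives > 100000 nM, which is a limit of the assay.
Compound 2 `C=CC1=C(C(=O)NCc2ccccc2F)C(c2ccc(F)cc2)OC1` — in this assay compound 2 gives 51400 nM.

Compound 1 therefore stands at the limit (the limit of > 100000 nM in this assay, at which 1 of the 2 values shown sits), with no number of its own. Compound 3 `C=CC1=C(C(=O)NCCC)C(c2ccc(OC)cc2)OC1` differs from compound 1 by methoxy in place of fluoro on an aromatic carbon. Among the measured compounds shown here, the only measured step, an at least 1.9-fold lower number from compound 1 to compound 2 (0.28 log units; that floor lies within the scatter), alters the group on the saturated chain carbon bound to the amide-type nitrogen and leaves the aromatic ring untouched, so it does not bear on this change. The step of a number no higher from compound 1 to compound 3 (the limit leaves the size open) is accordingly expected to be none beyond the scatter. Compound 3 is expected to give 100000 nM, between 40000 nM and 300000 nM.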

Compound 3, half-maximal inhibitory concentration: > 100000 nM
Compound 3: only a limit was reported (the forecaster's own chance of this, stated with the estimate: 70%); the middle value lies on the limit itself.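

Among the compounds shown here, no step from compound 1 to compound 3 can be read, since each carries only a limit of the assay: the limit of > 100000 nM in this assay, at which 2 of the 3 values shown sit.

On these data alone, whether methoxy in place of fluoro on an aromatic carbon shifts the number in this assay at all stays open.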